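Hydroxamic acid series: pyridin-4-yl replaces benzothiophene

The compounds below may be only part of what the source reports. "The series", "measured", "known", "first", "only" and "open" are said of these compounds alone.

Three compounds have been measured so far:
compound 1 `Cc1ccc(-n2nc(-c3ccccc3)nc2CNc2ccc(C(=O)NO)cc2)cc1` gives 60.7%;
compound 2 `COc1ccc(-n2nc(-c3ccc(O)cc3)nc2CNc2ccc(C(=O)NO)cc2)cc1` gives 70.3%;
compound 3 `O=C(NO)c1ccc(NCc2nc(-c3cc4ccccc4s3)nn2-c2ccccc2)cc1` gives 65.5%.

All three were tested in an assay on Sf9 cells for inhibition of protein deacetylase HDAC6 (Homo sapiens), read by fluorescence, with a stated time of 40 min, tested at 100 nM; a higher number here means more inhibition at the concentration tested (going by the name of the read-out), a lower number less inhibition. Compound 3 stands second highest of the three numbers, yet its nearest neighbour, compound 1, and its furthest, compound 2, both lie within the usual scatter, so the three values cannot be told apart. Compound 4 `O=C(NO)c1ccc(NCc2nc(-c3ccncc3)nn2-c2ccccc2)cc1` has not yet been measured. It differs from compound 3 in one place: pyridin-4-yl in place of 1-benzothiophen-2-yl on an aromatic carbon. For the measured compounds named here, no step between measured compounds is available for this change, and the three aryl groups already seen give numbers that do not separate. The step of a number 5.5 percentage points lower from compound 3 to compound 4 (within the scatter) is therefore expected to stay within the scatter. Compound 4 is estimated at 60%, with a range from 40% to 78%.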

Compound 4, a percentage reported as inhibition, at one concentration (the size of the read-out at that concentration, not a potency): 30.8%
Compound 4: the middle estimate sits 29.2 percentage points above what was measured; the whole stated range lies above it.
By their numbers in this assay, from the lowest: compound 4; then compounds 1, 3 and 2 (each within the scatter of the next).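

In this assay, the aromatic carbon of the five-membered aromatic ring with 3 nitrogen proves sensitive to the group it carries: pyridin-4-yl in place of 1-benzothiophen-2-yl brings a number 34.7 percentage points lower from compound 3 to compound 4 (beyond the scatter) at this position. The change replaces two aromatic rings with one and adds a ring nitrogen, and this single step cannot separate the two. No available evidence bears on the drop.

Still open, as far as these compounds go, is whether pyridin-3-yl or quinolin-2-yl at this carbon would restore the number. Also open, from the compounds shown here alone, is whether an amine on the pyridine ring would shift it.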